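A few compounds are considered here, and "the series" means these few. Any claim that something is new, unique, unknown or untested is made for them only; others in the source may bear on it.

Measured so far in a functional assay on HFF cells (Homo sapiens) for cytotoxicity; a higher number here means a weaker inhibitor, a lower number a stronger inhibitor:
compound 1, `Cc1nc(N(C)Cc2ccccc2)nc(-n2ccnc2C)c1[N+](=O)[O-]`: > 100000 nM
compound 2, `Cc1nc(NC2CCc3ccccc32)nc(-n2ccnc2C)c1[N+](=O)[O-]`: > 100000 nM

In this assay compound 1 gives > 100000 nM; this is a limit of the assay, not a number. Compound 2 gives > 100000 nM in this assay, again a limit rather than a number. Going by the values given here, compound 1 therefore stands at the limit of > 100000 nM in this assay, at which 2 of the 2 values shown sit, and the one other value shown sits at the same limit, so no order between compound 1 and compound 2 can be read from these values, and no step between measured compounds is available.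

Compound 3, `Cc1nc(N(C)c2ccccc2)nc(-n2ccnc2C)c1[N+](=O)[O-]`, is not yet measured in this assay. It differs from compound 1 by phenyl in place of benzyl on a nitrogen on an aromatic ring. With both known members of the series at the limit, the step in this assay is expected to be none beyond the scatter, with compound 3 most likely reported as a limit as well. For compound 3 the estimated value in this assay is 150000 nM, with an expected range from 50000 nM to 500000 nM. The expected step that the limit leaves unreadable from compound 1 to compound 3 is thus essentially flat.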

Compound 3, half-maximal inhibitory concentration: 100000 nM
Estimate against measurement, compound 3: 1.5-fold (0.18 log units) above, within the range that was stated.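

In this assay compound 3 gives 100000 nM, the first read-out in the series that is a number and not a limit. With phenyl in place of benzyl on a nitrogen on an aromatic ring, the series shows a number no higher from compound 1 to compound 3 (the limit leaves the size open), so this position now has one substituent with a readable value, though the comparison gives a direction only and no size. The other two values shown remain at a single limit, which still sets the frame for reading this change: the limit of > 100000 nM in this assay, at which 2 of the 3 values shown sit.

The compounds shown leave open how far the value in this assay can move at this nitrogen, since only phenyl gives a number there so far. Going by these compounds, whether an amine or a carboxylic acid on the phenyl of compound 3, or a longer chain in place of its phenyl, would give a value clearly different from that of compound 3 also remains open.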